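Thiophen-2-yl in place of 1H-pyrrol-2-yl: working notes

The source may hold more compounds than are shown below. What is called first, only, known or untested is meant among the compounds shown, and "the series" means these compounds.

In a functional assay on A2780 cells (Homo sapiens) for inhibition, read by sulforhodamine B assay, with a stated time of 3 days (on this read-out higher numbers stand for weaker inhibition and lower numbers for stronger inhibition), compound 1 (`O=C1Nc2ccc(F)cc2/C1=C\C(=O)c1ccc(O)cc1F`) gives 1580 nM and compound 2 (`O=C1Nc2ccc(F)cc2/C1=C\C(=O)c1ccc[nH]1`) gives 2170 nM on the same read-out. These two values lie within the usual scatter of each other, so compound 2 stands level with compound 1. Compound 3 (`O=C1Nc2ccc(F)cc2/C1=C\C(=O)c1cccs1`) keeps the shared core and differs from compound 2 in one place, with thiophen-2-yl in place of 1H-pyrrol-2-yl on a carbonyl carbon. Going by the values given here, no measured pair isolates a change of this kind. The groups on the carbonyl carbon of compound 1 and compound 2 differ, yet their values stay within the scatter. No shift beyond the scatter is therefore expected in this assay, in either direction. The expected change is a 1.3-fold lower number from compound 2 to compound 3 (0.11 log units; within the scatter) and stays within the scatter. Compound 3 is estimated at 1700 nM with an expected range of 750 nM to 3900 nM on this read-out.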

Compound 3, half-maximal inhibitory concentration: 2750 nM
Estimate against measurement, compound 3: 1.6-fold (0.21 log units) below; measured number inside the range.
By their numbers in this assay, from the lowest: compounds 1, 2 and 3 (each within the scatter of the next).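

In this assay, going by these compounds alone, the step on the carbonyl carbon reads a 1.3-fold higher number from compound 2 to compound 3 (0.10 log units; within the scatter) and is the first single-place comparison at this position. The change removes the hydrogen-bond donor counted on 1H-pyrrol-2-yl and adds the hydrogen-bond acceptor counted on thiophen-2-yl, yet the step stays within the scatter, so this pair shows no dependence of the read-out on that exchange. No measurement shown here offers an explanation for this result.

Open, going by these compounds, is whether furan-2-yl or pyridin-3-yl on the carbonyl carbon would also stay within the scatter, and whether a group carrying an amine or a carboxylic acid would move the number beyond it. So far, no single-place step at this position lies beyond the scatter, so the range of groups tolerated here remains undefined.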